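Carboxy to Hydroxymethyl: An Untested Swap in Compound 2

The source may report more compounds than this note shows. Statements on the series, on what has been measured and on what is new or still open speak of the compounds shown alone.

Three compounds share a saturated six-membered ring with one oxygen, each bearing a carboxy group. Compound 1 `CC[C@@H]1CCC[C@H](C(=O)O)O1` carries a small group there, while compound 2 `O=C(O)[C@H]1CCC[C@@H](c2ccc3ccccc3c2)O1` and compound 3 `O=C(O)[C@H]1CCC[C@@H](c2cccc3ccccc23)O1` carry a large group. In a functional assay on the whole organism (Abdomen, strain Swiss albino) for inhibition, with Mus musculus as the target, in the writhing test, with a stated time of 30 min, at a dose of 30 mg/kg by the oral route (on this read-out higher numbers stand for more inhibition at the one dose given (going by the name of the read-out) and lower numbers for less inhibition), compound 1 gives 14.1%, compound 2 gives 43.1%, and compound 3 gives 49%. Compound 2 thus stands second of the three: its number lies within the scatter of compound 3 and well beyond the scatter above compound 1. Compound 4 `OC[C@H]1CCC[C@@H](c2ccc3ccccc3c2)O1` is not yet measured; it differs from compound 2 by hydroxymethyl in place of carboxy on a saturated ring carbon. Within the data shown here, no measured pair shows this change, so its effect is unknown. Still, a downward step beyond the scatter is expected, a number 15.1 percentage points lower from compound 2 to compound 4 (beyond the scatter). Compound 4 is estimated at 28%, between 10% and 50%.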

Compound 4, a percentage reported as inhibition, in the whole organism at one dose (the size of the read-out at that dose, not a potency): 55.7%
Estimate against measurement, compound 4: 27.7 percentage points below; measured number above the stated range.
By their numbers in this assay, from the lowest: compound 1; then compounds 2, 3 and 4 (each within the scatter of the next, the first and the last beyond it).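

Putting hydroxymethyl in place of carboxy on this saturated ring carbon, next to the ring oxygen, gives a number 12.6 percentage points higher from compound 2 to compound 4 (beyond the scatter) in this assay and so does not lower the inhibition. Among these compounds, all the earlier compounds carried carboxy here, so they could not show that, with this large group on the core, inhibition at this one dose does not depend on a carboxy group at this position.

On these data alone, whether an amine or a methyl ester here would do as well remains open, as does whether the same swap would act alike on the cores of compound 1 and compound 3. Nothing shown explains the step.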